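Nucleoside triazoles: tert-butyl on the benzyl ring

This account rests on a few compounds, and the source may have more. Where it says the series, first, only, none or still open, it means among the compounds named here.

Measured compounds:
compound 1, `CC(=O)OC[C@H]1O[C@@H](n2cc(-c3cn(Cc4ccccc4)nn3)c(=O)[nH]c2=O)C[C@@H]1OC(C)=O`, gives 88.7% in a functional assay on NUGC-3 cells (Homo sapiens) for cytotoxicity, read by sulforhodamine B assay, tested at 10 uM; on this read-out higher numbers stand for more inhibition at the one concentration tested (going by the name of the read-out) and lower numbers for less inhibition
compound 2, `CC(C)(C)c1ccc(Cn2cc(-c3cn([C@H]4C[C@H](O)[C@@H](CO)O4)c(=O)[nH]c3=O)nn2)cc1`, gives 94.8%
compound 3, `O=c1[nH]c(=O)n([C@H]2C[C@H](O)[C@@H](CO)O2)cc1-c1cn(Cc2ccccc2)nn1`, gives 95.6%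

Compound 2 and compound 3 differ by one change, (tert-butyl in place of hydrogen on an aromatic carbon), and that change gave a number 0.8 percentage points lower from compound 3 to compound 2 (within the scatter). Compound 1 carries a different core from compound 3; the difference between the two cores is not broken down here. Compound 4, `CC(=O)OC[C@H]1O[C@@H](n2cc(-c3cn(Cc4ccc(C(C)(C)C)cc4)nn3)c(=O)[nH]c2=O)C[C@@H]1OC(C)=O`, is not yet measured; it is reached from compound 1 by tert-butyl in place of hydrogen on an aromatic carbon, the same change as from compound 3 to compound 2, at the same place.

Because the earlier step was a number 0.8 percentage points lower from compound 3 to compound 2 (within the scatter), the step from compound 1 to compound 4 is expected to be of similar size, a number 0.3 percentage points higher from compound 1 to compound 4 (within the scatter). Compound 4 is therefore estimated at 89%, between 78% and 97%.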

Compound 4, a percentage reported as inhibition, at one concentration (the size of the read-out at that concentration, not a potency): 94.2%
The estimate for compound 4 lay 5.2 percentage points below the measured number; low and high end bracket the measured number.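

In this assay, tert-butyl in place of hydrogen on the benzyl ring gives a number 5.5 percentage points higher from compound 1 to compound 4 (within the scatter). Set beside the same change on the other core, this step does not differ from the earlier one: the same change on two cores in this assay, a number 0.8 percentage points lower (within the scatter) from compound 3 to compound 2 and a number 5.5 percentage points higher (within the scatter) from compound 1 to compound 4, 6.3 percentage points apart, within the scatter of two such steps. The change thus carries across these two cores without a detectable difference, but neither step stands clear of the scatter, and a reading at one concentration is no potency, so no effect of tert-butyl on either core is shown.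

The compounds shown carry only hydrogen or tert-butyl at this place on the benzyl ring. From the compounds shown here alone, how an amine, a carboxylic acid or chlorine there would read remains open, as does a longer chain in place of the benzyl group.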